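Adding a Second Piperidine to a Stable Compound

The compounds below may be only part of what the source reports. "The series", "measured", "known", "first", "only" and "open" are said of these compounds alone.

Compound 1 `c1cc2c(C3CCNCC3)c[nH]c2cc1Nc1ccc2c(C3CCNCC3)c[nH]c2c1`: 89%
Compound 2 `N#Cc1c[nH]c2nc(Nc3ccc4c(C5CCNCC5)c[nH]c4c3)ccc12`: 100%

In an ADME assay on microsomes from liver (Homo sapiens) for metabolic stability, with a stated time of 1 h (on this read-out lower numbers stand for a less stable compound and higher numbers for a more stable compound), compound 2 stands highest of the two measured compounds at 100%, while compound 1 gives 89%, a gap beyond the scatter. Compound 3 `c1cc2c(C3CCNCC3)c[nH]c2cc1Nc1ccc2c(C3CCNCC3)c[nH]c2n1` differs from compound 2 by one change, piperidin-4-yl in place of cyano on an aromatic carbon. Among the measured compounds shown here, no measured pair shows this change directly. For the measured compounds named here, the only guide is compound 1, which also carries piperidin-4-yl and gives 89%. A downward move of about the size of the scatter is therefore expected, and the estimated step is a number 10 percentage points lower from compound 2 to compound 3 (within the scatter). For compound 3 the estimate is 90%, with an expected range from 74% to 100%.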

Compound 3, percent of the compound remaining in the liver assay: 95%
Compound 3: middle estimate off by 5 percentage points, on the low side; measured number inside the range.
By their numbers in the liver assay, from the lowest: compounds 1, 3 and 2 (each within the scatter of the next, the first and the last beyond it).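

In the liver assay compound 2 gives 100% and compound 3 gives 95%. In the liver assay, piperidin-4-yl in place of cyano on an aromatic carbon of the five-membered aromatic ring gives a number 5 percentage points lower from compound 2 to compound 3 (within the scatter) and so shows that this place accepts a six-membered non-aromatic ring without a step beyond the scatter. In a physicochemical assay for solubility, in phosphate buffer, at pH 7.4 (a higher number here means a more soluble compound, a lower number a less soluble compound), compound 2 gives 196000 nM and compound 3 gives 166000 nM. In the physicochemical assay the same change gives a 1.2-fold lower number from compound 2 to compound 3 (0.07 log units; within the scatter) and stays within the scatter there too. Nothing available explains why either read-out holds. On these data alone, what an aminomethyl group or a carboxylic acid at this place would do in the liver assay and in the physicochemical assay stays open.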